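From Dichlorophenyl to Dimethoxyphenyl on the Carbonyl Carbon

A few compounds are considered here, and "the series" means these few. Any claim that something is new, unique, unknown or untested is made for them only; others in the source may bear on it.

Of the compounds shown here, three built on one shared core have been tested in a functional assay on TK-10 cells (Homo sapiens) for inhibition, read by sulforhodamine B assay, with a stated time of 48 h; a higher number here means that more compound is tolerated, a lower number that less compound is tolerated. Compound 1 `COc1cc(-c2cc(/C=C/C(=O)c3ccc(Cl)c(Cl)c3)[nH]n2)cc(OC)c1OC` reaches only the limit of this assay, giving > 100000 nM, which is a boundary and not a number. Among the compounds with values here, this boundary is the point at which one of the three values so far sits (the limit of > 100000 nM in this assay, at which 1 of the 3 values shown sits). Compound 2 `COc1ccc(-c2cc(/C=C/C(=O)c3ccc(N)cc3)[nH]n2)cc1OC` gives 48700 nM in this assay, and compound 3 `COc1ccc(-c2cc(/C=C/C(=O)c3cc(OC)c(OC)c(OC)c3)[nH]n2)cc1OC` gives 36900 nM; these two values lie within the usual scatter of each other, so no order between them can be claimed.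

Compound 4 `COc1ccc(C(=O)/C=C/c2cc(-c3cc(OC)c(OC)c(OC)c3)n[nH]2)cc1OC` has not yet been measured. Against compound 1 it carries 3,4-dimethoxyphenyl in place of 3,4-dichlorophenyl on a carbonyl carbon. Within the data shown here, no pair of measured compounds differs in a single place, so no measured step is available to set the size of this change. What can be said is that compound 2 and compound 3, which do not carry the 3,4-dichlorophenyl, both give a number rather than a limit in this assay. Compound 4 is therefore expected to give a measurable value, estimated at 50000 nM, within a range from 15000 nM to 150000 nM. The step of an at least 2.0-fold lower number from compound 1 to compound 4 (0.30 log units; that floor lies within the scatter) is expected to run toward a lower number, from a limit down to a value, though the measurement alone can confirm this.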

Compound 4, concentration lethal to 50% of the cells: 5100 nM
Compound 4: middle estimate off by 9.8-fold (0.99 log units), on the high side; the measured number lies below the stated range.
By their numbers in this assay, from the lowest: compound 4; then compounds 3 and 2 (each within the scatter of the next). At a limit, above all of these: compound 1.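

In this assay, within the data shown here, the only step between two measured compounds that differ in one place is now available: 3,4-dimethoxyphenyl in place of 3,4-dichlorophenyl on a carbonyl carbon gives an at least 19-fold lower number from compound 1 to compound 4 (1.29 log units; beyond the scatter). This shows that the group on this carbonyl carbon matters for the read-out, since this single exchange, with the rest of the structure unchanged, moves the number well beyond the scatter and toward less compound being tolerated. The step is a floor and its true size stays unknown, because compound 1 gives only a limit and not a number: the limit of > 100000 nM in this assay, at which 1 of the 4 values shown sits.

The compounds shown cannot tell whether the gain comes from the two methoxy groups together, from one of them alone, or from the loss of one or both chlorines, so a 4-methoxyphenyl, a 3-methoxyphenyl or a 3,4-dihydroxyphenyl on the same carbonyl carbon would each be informative. From the compounds shown here alone, it also remains open how a quite different group at this place, such as a carboxylic acid, would read, and whether the same exchange on another cell line would run the same way.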